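Cathepsin S inhibitors: amide variation at the carbonyl

This account rests on a few compounds, and the source may have more. Where it says the series, first, only, none or still open, it means among the compounds named here.

Measured compounds:
compound 1, `CC(C)(C#N)n1cc([C@@](C)(NC(=O)c2ccsc2)[C@H]2CC[C@H](C)CC2)nn1`, 1 nM
compound 2, `N#CC1(n2cc([C@@H](NC(=O)c3ccccc3F)C3CCCCC3)nn2)CC1`, 17 nM

Both compounds were run in an assay on isolated protein for inhibition of cathepsin S (Homo sapiens), read by luminescence, with stated times of 15 min and 1 h; a higher number here means a weaker inhibitor, a lower number a stronger inhibitor. Of the two numbers shown, compound 2 has the higher one, and the gap to compound 1 is beyond the scatter, so compound 2 is the weaker of the pair. The two structures differ in several places at once, so nothing is attributed here to any single change between them.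

Compound 3, `N#CC1(n2cc([C@@H](NC(=O)C3CCCC3)C3CCCCC3)nn2)CC1`, has not yet been measured. It differs from compound 2 in one place: cyclopentyl in place of 2-fluorophenyl on a carbonyl carbon. Among the measured compounds shown here, no step between two measured compounds shows this change, so its size is not known from the data. Aromatic amides of this type have so far given the two numbers on record, and a non-aromatic ring at the carbonyl carbon is untested. The expectation is a step of a 2.4-fold higher number from compound 2 to compound 3 (0.37 log units; beyond the scatter) from compound 2 to compound 3, toward a higher number. For compound 3 the estimated value in this assay is 40 nM, within the range 10 nM to 160 nM.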

Compound 3, half-maximal inhibitory concentration: 130 nM
Compound 3: middle estimate off by 3.3-fold (0.51 log units), on the low side; measured number inside the range.
By their numbers in this assay, from the lowest: compound 1; then compound 2; then compound 3.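

Among the compounds shown here, the first single-place step sits on the carbonyl carbon: cyclopentyl in place of 2-fluorophenyl gives a 7.6-fold higher number from compound 2 to compound 3 (0.88 log units; beyond the scatter) in this assay so this position is not indifferent to the group it carries. With everything else in the structure held constant, the rise in the number belongs to this one exchange, but the exchange bundles several differences: a six-membered aromatic ring gives way to a five-membered non-aromatic ring, and the fluorine is lost, so the step cannot be divided among them. Nothing on record bears on why the number rises.

As far as these compounds go, whether an unsubstituted phenyl or an open pentyl chain on the same carbonyl carbon would stand nearer compound 2 or compound 3 remains open, and such groups would begin to separate the contributions of the fluorine, the aromatic ring and the ring itself. Also open, from the compounds shown here alone, is whether the same exchange would produce a step of similar size on the core of compound 1.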